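Oxetan-3-yl in Place of a Fluorinated Hydroxypropyl Chain

The source may report more compounds than this note shows. Statements on the series, on what has been measured and on what is new or still open speak of the compounds shown alone.

Measured so far:
Compound 1, `CS(=O)(=O)CCCn1c(Cn2nc(S(C)(=O)=O)c3ccncc32)nc2cc(Cl)ccc21`, an ADME assay on HEp-2 cells (Homo sapiens) for cytotoxicity, with a stated time of 4 days; a higher number here means that more compound is tolerated, a lower number that less compound is tolerated: > 100000 nM
Compound 2, `CC(C)(CO)Cn1c(Cn2nc(S(C)(=O)=O)c3ccncc32)nc2cc(Cl)ccc21`: > 100000 nM
Compound 3, `CS(=O)(=O)c1nn(Cc2nc3cc(Cl)ccc3n2CCC(O)C(F)(F)F)c2cnccc12`: > 100000 nM

All three values are limits of the assay, not numbers. For compound 1 the reading > 100000 nM is such a limit. For compound 2 the reading > 100000 nM is likewise a limit. For compound 3 the reading > 100000 nM is again a limit. The steps among them cannot be sized: a step that the two limits leave unreadable from compound 1 to compound 2, a step that the two limits leave unreadable from compound 1 to compound 3 and a step that the two limits leave unreadable from compound 2 to compound 3. What the data do show is the limit of > 100000 nM in this assay, at which 3 of the 3 values shown sit.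

Compound 4, `CS(=O)(=O)c1nn(Cc2nc3cc(Cl)ccc3n2CC2COC2)c2cnccc12`, has not yet been measured. It differs from compound 3 in one place: oxetan-3-yl in place of 3,3,3-trifluoro-2-hydroxypropyl on a saturated chain carbon bound to an aromatic nitrogen. Within the data shown here, no measured step bears directly on this change, since none of the three known steps can be read. Given that every compound so far sits at the same limit, the expectation for compound 4 is that it remains there as well, and the estimated step from compound 3 is a number no higher from compound 3 to compound 4 (the limit leaves the size open), meaning no change beyond the scatter. Compound 4 is therefore expected to read about 100000 nM, within 30000 nM to 300000 nM, most likely reported again as a limit.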

Compound 4, half-maximal cytotoxic concentration: > 100000 nM
Compound 4: no number, only a limit (the forecaster's own chance of this, stated with the estimate: 85%); the middle value lies on the limit itself.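

In this assay compound 4 reads > 100000 nM, which is a limit of the assay and not a number. No step from compound 1, compound 2 or compound 3 to compound 4 can be read: the limit of > 100000 nM in this assay, at which 4 of the 4 values shown sit.

The compounds shown leave open whether their differing chains separate them at all in this assay.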